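Aryl versus alkyl amides on the shared core

The source may hold more compounds than are shown below. What is called first, only, known or untested is meant among the compounds shown, and "the series" means these compounds.

Compounds measured in an assay on isolated protein for inhibition of aldehyde dehydrogenase 1A1 (Homo sapiens), read by spectrophotometry, tested at 10 uM; a higher number here means more inhibition at the concentration tested (going by the name of the read-out), a lower number less inhibition:

compound 1 `Cc1cccc(Cn2c(CN3CCN(C(=O)c4ccc(C(F)(F)F)cc4)CC3)nc3ccccc32)c1` gives 22.9%
compound 2 `Cc1cccc(Cn2c(CN3CCN(C(=O)CC(C)C)CC3)nc3ccccc32)c1` gives 71.4%
compound 3 `Cc1cccc(Cn2c(CN3CCN(C(=O)c4ccncc4)CC3)nc3ccccc32)c1` gives 20.6%

Compound 3 holds the lowest of the three numbers in this assay. Its nearest neighbour is compound 1, and the step of a number 2.3 percentage points lower from compound 1 to compound 3 (within the scatter) is within the scatter, so the two aryl amides cannot be told apart. Among the compounds with values here, the step of a number 50.8 percentage points lower from compound 2 to compound 3 (beyond the scatter) is beyond the scatter and large; the only compound that stands clearly apart is compound 2, the one with isobutyl on the carbonyl carbon, as also seen in the step of a number 48.5 percentage points higher from compound 1 to compound 2 (beyond the scatter).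

Compound 4 `Cc1cccc(Cn2c(CN3CCN(C(=O)c4cccs4)CC3)nc3ccccc32)c1` is not yet measured. It differs from compound 3 by thiophen-2-yl in place of pyridin-4-yl on a carbonyl carbon. Within the data shown here, the steps that bear on it are those between the two aryl amides, compound 1 and compound 3, which differ only within the scatter, and those to the isobutyl amide compound 2, which are large. Compound 4 keeps an aromatic ring on the carbonyl carbon, so no step beyond the scatter is expected from compound 3 to compound 4, and the estimated step is a number 4.4 percentage points higher from compound 3 to compound 4 (within the scatter). The expected value for compound 4 in this assay is 25%, with a range from 10% to 45%.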

Compound 4, a percentage reported as inhibition, at one concentration (the size of the read-out at that concentration, not a potency): 60.8%
The estimate for compound 4 lay 35.8 percentage points below the measured number; the whole stated range lies below it.
By their numbers in this assay, from the lowest: compounds 3 and 1 (each within the scatter of the next); then compound 4; then compound 2.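

Working notes on the amide position, read in this assay: an aromatic ring on the carbonyl carbon does not by itself hold the number low, since thiophen-2-yl in place of pyridin-4-yl gives a clear rise (a number 40.2 percentage points higher from compound 3 to compound 4 (beyond the scatter)) and thiophen-2-yl in place of 4-(trifluoromethyl)phenyl gives a rise of similar size (a number 37.9 percentage points higher from compound 1 to compound 4 (beyond the scatter)). The earlier split into low aryl amides and a high alkyl amide therefore does not hold, and the isobutyl amide keeps only a modest lead over the thiophene amide (a number 10.6 percentage points lower from compound 2 to compound 4 (beyond the scatter)). Among the compounds shown, the two six-membered aromatic rings sit low and the five-membered one sits high, while no measurement on hand gives a reason for this difference.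

Ring size and the identity of the hetero atom change together in the step to thiophen-2-yl, so the data cannot assign the rise to either one. Furan-2-yl, thiophen-3-yl and an unsubstituted phenyl on the same carbonyl carbon would separate these, and cyclopentyl would show how a five-membered ring without aromatic character compares with isobutyl.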